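This account rests on a few compounds, and the source may have more. Where it says the series, first, only, none or still open, it means among the compounds named here.

Measured compounds:
- compound 1, `Cc1cc(C)cc(Cc2ccc3c(NCCCNCc4ccco4)ccnc3c2)c1`, 9.47
- compound 2, `COc1ccccc1Oc1ccc2c(NCCCNCc3ccco3)ccnc2c1`, 9.28
- compound 3, `Fc1ccc(Cc2ccc3c(NCCCNCc4ccco4)ccnc3c2)c(Cl)c1`, 9.47

In a physicochemical assay for acid dissociation, compound 2 gives 9.28, the lowest of the three numbers, yet both neighbours sit within the scatter of it: a number 0.19 log units lower from compound 1 to compound 2 (within the scatter) and a number 0.19 log units higher from compound 2 to compound 3 (within the scatter). Across these three compounds only the group on the aromatic carbon of the shared core was exchanged, and none of those exchanges moved the number beyond the scatter.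

Compound 4, `COc1ccc(F)cc1CNCCCNc1ccnc2cc(Oc3ccccc3OC)ccc12`, differs from compound 2 elsewhere: 5-fluoro-2-methoxyphenyl in place of furan-2-yl on a saturated chain carbon bound to an amine nitrogen. For the measured compounds named here, no measured step touches this part of the molecule, so none bears directly on the change. Going by the values given here, the measured steps, a number 0.19 log units lower from compound 1 to compound 2 (within the scatter), no change at the digits printed from compound 1 to compound 3 (within the scatter) and a number 0.19 log units higher from compound 2 to compound 3 (within the scatter), show only that changes remote from the amine leave this assay unmoved. On that basis compound 4 is expected to stay close to compound 2, with a number 0.22 log units higher from compound 2 to compound 4 (within the scatter) as the estimated step. The estimate for compound 4 is 9.5, within 9 to 10.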

Compound 4, acid dissociation constant: 9.28
Compound 4: the middle estimate sits 0.22 log units above what was measured; the measured number falls inside the stated range.
By their numbers in this assay, from the lowest: compounds 2, 4, 1 and 3 (each within the scatter of the next).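

For the compounds shown here, compound 4 gives the first reading at the saturated chain carbon bound to an amine nitrogen, where the earlier compounds varied only the group on an aromatic carbon of the shared core. In this assay, placing 5-fluoro-2-methoxyphenyl where furan-2-yl stood gives no change at the digits printed from compound 2 to compound 4 (within the scatter), so this exchange of a five-membered aromatic ring with 1 hetero atom for a larger six-membered aromatic ring of carbon only leaves the number within the scatter. No measurement shown accounts for this outcome.

Going by these compounds, both compounds in this step carry 2-methoxyphenoxy, so it remains open whether the same exchange would read alike with the 3,5-dimethylbenzyl of compound 1. Also open, on these data alone, is how this assay would respond to a carboxylic acid or a second amine at this place, or to a longer chain between the two nitrogens.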